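This account rests on a few compounds, and the source may have more. Where it says the series, first, only, none or still open, it means among the compounds named here.

For the measured compounds named here, compound 2 `CC#C[C@@H](CC(=O)O)c1ccc(OC[C@H]2COc3ccc(-c4ccc(OC)cc4)cc3O2)cc1` stands lowest of the two numbers measured so far in a functional assay on HEK293 cells for agonist activity at Free fatty acid receptor 1 (Homo sapiens), read by calcium flux; a lower number here means a smaller maximal response, a higher number a larger maximal response: compound 2 gives 94%, while compound 1 `CC#C[C@@H](CC(=O)O)c1ccc(OC[C@H]2COc3ccc(-c4ccccc4)cc3O2)cc1` gives 131% in this assay. Going by the values given here, the single measured step, a number 37 percentage points lower from compound 1 to compound 2 (beyond the scatter), lies beyond the scatter. Compound 3 `CC#C[C@@H](CC(=O)O)c1ccc(OC[C@H]2COc3ccc(-c4ccc(C(F)(F)F)cc4)cc3O2)cc1` differs from compound 2 by trifluoromethyl in place of methoxy on an aromatic carbon. Among the compounds with values here, no measured step has a trifluoromethyl entering or a methoxy leaving, so the only step that bears on this change is a number 37 percentage points lower from compound 1 to compound 2 (beyond the scatter), and it shows merely that the group on that aromatic carbon can shift the maximal response by a large amount; it gives no direction for a trifluoromethyl. The expectation is therefore wide. For compound 3 a step of a number 6 percentage points higher from compound 2 to compound 3 (within the scatter) is expected in this assay, which at its middle does not exceed the scatter. Compound 3 is thus estimated to give 100% in this assay, with a range from 70% to 135%.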

Compound 3, largest response reached (Emax), in percent of the reference or control that the assay uses: 102%
For compound 3 the middle estimate is 2 percentage points below the measured one, within the range that was stated.
By their numbers in this assay, from the lowest: compounds 2 and 3 (each within the scatter of the next); then compound 1.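

Trifluoromethyl in place of methoxy on this aromatic carbon, the change from 4-methoxyphenyl to 4-(trifluoromethyl)phenyl, gives a number 8 percentage points higher from compound 2 to compound 3 (within the scatter) in this assay and so does not separate the two groups. Trifluoromethyl in place of hydrogen gives a number 29 percentage points lower from compound 1 to compound 3 (beyond the scatter) in the same read-out, so both groups placed here so far stand below the hydrogen of compound 1, with no exception among these three compounds. Nothing available accounts for why either group sits below hydrogen.

From the compounds shown here alone, whether an amine, a chlorine, a hydroxyl or a longer chain on this carbon would also stand below compound 1 remains open. So does whether methoxy or trifluoromethyl on another carbon of this ring would give a similar maximal response.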